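The compounds below may be only part of what the source reports. "The series", "measured", "known", "first", "only" and "open" are said of these compounds alone.

Compound 2, with the structure `COc1cc2ncnc(-n3nc(-c4ccccn4)nc3N)c2cc1OCCCCNC(=O)OC(C)(C)C`, holds the lower of the two numbers measured in an assay on MCF7 cells for inhibition of Serine-protein kinase ATM (Homo sapiens), read by immunofluorescence, with a stated time of 1 h (a lower number here means a stronger inhibitor, a higher number a weaker inhibitor), where compound 2 gives 800 nM. Among the compounds with values here, the only other measured compound, compound 1 with the structure `COc1cc2ncnc(-n3nc(-c4ccccn4)nc3N)c2cc1OCCCNC(=O)CN1C[C@@H](C)O[C@@H](C)C1`, gives 1700 nM in this assay. Within the data shown here, the single measured step, a 2.1-fold lower number from compound 1 to compound 2 (0.33 log units; beyond the scatter), shows that exchanging the group at the end of the chain shifted the number only modestly. Compound 3 has the structure `COc1cc2ncnc(-n3nc(-c4ccccn4)nc3N)c2cc1OCCCNC(=O)C(F)(F)F`. It differs from compound 2 at the same place: ((trifluoromethyl)carbonyl)amino in place of ((tert-butoxycarbonyl)amino)methyl on a saturated chain carbon, three bonds along the chain from an oxygen on an aromatic ring. Among the measured compounds shown here, no measured step covers this exact change, so the expectation rests on the one step available. Because a 2.1-fold lower number from compound 1 to compound 2 (0.33 log units; beyond the scatter) was modest even though a large ring-bearing group was swapped for a carbamate, the step of a 1.1-fold higher number from compound 2 to compound 3 (0.05 log units; within the scatter) is expected to be small, quite possibly within the scatter, with no firm direction. Compound 3 is therefore estimated at 900 nM in this assay, with a range from 400 nM to 2200 nM.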

Compound 3, half-maximal inhibitory concentration: 2900 nM
For compound 3 the middle estimate is 3.2-fold (0.51 log units) below the measured one; the measured number lies above the stated range.
By their numbers in this assay, from the lowest: compound 2; then compounds 1 and 3 (each within the scatter of the next).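

Moving from the 4-((tert-butoxycarbonyl)amino)butyl end of the chain to 3-(((trifluoromethyl)carbonyl)amino)propyl gives a step beyond the scatter in this assay (a 3.6-fold higher number from compound 2 to compound 3 (0.56 log units; beyond the scatter)), so this position is not indifferent to what it carries, as the single earlier step could only hint. On the carbonyl carbon, by contrast, trifluoromethyl in place of (2,6-dimethylmorpholin-4-yl)methyl leaves the numbers within the scatter (a 1.7-fold higher number from compound 1 to compound 3 (0.23 log units; within the scatter)), so two very different groups at that spot are not told apart here, and compound 2, the only one with the butyl chain and the tert-butoxycarbonyl group, alone stands apart from the other two. Nothing measured here accounts for these numbers.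

In compound 2 the longer chain and the tert-butoxycarbonyl group occur together, so the compounds shown cannot say which of the two goes with its lower number; a tert-butoxycarbonylamino group on a propyl chain, or a trifluoromethyl amide on a butyl chain, would separate them. Going by these compounds, how a free amine or a carboxylic acid at the chain end would read in this assay also remains open.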